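Replacing the 2-(3,5-dichlorophenyl)ethyl group of compound 1

This account rests on a few compounds, and the source may have more. Where it says the series, first, only, none or still open, it means among the compounds named here.

Compound 1 `O=C(NC[C@@H]1[C@H]2CN(C(=O)CCc3cc(Cl)cc(Cl)c3)C[C@@H]12)c1ccc2[nH]c(=O)oc2c1` is the starting point for this step in a physicochemical assay for solubility, with a stated time of 24 h, at pH 2.2; a higher number here means a more soluble compound, a lower number a less soluble compound. Compound 1 gives < 1 ug/mL, which is a limit of the assay and not a number. Compound 2 `N#Cc1cc(COC(=O)N2C[C@@H]3[C@@H](CNC(=O)c4ccc5[nH]c(=O)oc5c4)[C@@H]3C2)cc(OC(F)(F)F)c1` gives < 1 ug/mL, which is also a limit. Within the data shown here, the data so far amount to the limit of < 1 ug/mL in this assay, at which 2 of the 2 values shown sit, so neither compound has a number and no measured step is available for scaling.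

Compound 3 `Cc1ccc(COC(=O)N2C[C@@H]3[C@@H](CNC(=O)c4ccc5[nH]c(=O)oc5c4)[C@@H]3C2)nc1` is the next compound to be read. The change is a group of 9 heavy atoms (7 carbon, 1 nitrogen, 1 oxygen; one six-membered aromatic ring with 1 hetero atom) in place of a group of 10 heavy atoms (8 carbon, 2 chlorine; one six-membered aromatic ring of carbon only), on a carbonyl carbon: a group with one six-membered aromatic ring with 1 hetero atom takes the place of 2-(3,5-dichlorophenyl)ethyl, on a carbonyl carbon.

In this assay, a rise beyond the usual scatter is expected, although this is a judgement from the structural change alone. The estimated step is an at least 30-fold higher number from compound 1 to compound 3 (1.47 log units; beyond the scatter). Its size is poorly fixed, and another limit remains possible. The expectation starts from compound 1 at < 1 ug/mL, a limit that leaves the lower reference open. For compound 3, the expected value is 30 ug/mL, with an estimated range of 3 ug/mL to 200 ug/mL.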

Compound 3, solubility: > 92 ug/mL
Compound 3 gave a limit, no number; the forecaster's own chance of this, stated with the estimate: 15%; at least 3.0-fold (0.48 log units) between middle value and limit.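

In this assay compound 3 gives > 92 ug/mL, a limit of the assay and not a number. The carbonyl carbon whose other neighbour is the amide-type nitrogen in a ring is now shown to be a place where a single exchange can carry an at least 92-fold higher number from compound 1 to compound 3 (1.96 log units; beyond the scatter), the first step in the series that leaves the lower limit, although neither of its ends is a number: the limit of > 92 ug/mL in this assay, at which 1 of the 3 values shown sits A change at this place is not enough in every case: the 2-(3,5-dichlorophenyl)ethyl group of compound 1 is also gone from compound 2, which gives < 1 ug/mL, a limit of the assay and not a number.

The exchange from compound 1 to compound 3 alters the ring, its hetero atom and the atoms that join it to the carbonyl carbon all at once, so the compounds shown do not tell which of these parts carries the step. They also leave open how a ring bearing a dimethylamino group or a carboxylic acid, or a longer chain to the ring, would read here, and where compound 3 itself lies beyond its limit.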